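Butyl versus phenyl on the oxadiazole of compound 2

The compounds below may be only part of what the source reports. "The series", "measured", "known", "first", "only" and "open" are said of these compounds alone.

Measured so far:
compound 1 `CCCCc1noc(-c2ccc(C(=O)NC[C@@H]3CCCC3(C)C)cc2)n1` — 9 nM
compound 2 `CC(C)(C)CCNC(=O)c1ccc(-c2nc(-c3ccccc3)no2)cc1` — 130 nM

In an assay for activation of potassium voltage-gated channel subfamily KQT member 1 (Cavia porcellus) (a lower number here means a stronger inhibitor, a higher number a weaker inhibitor), compound 2 gives 130 nM, the higher of the two numbers in hand. Its nearest neighbour is compound 1, which in this assay gives 9 nM; the gap between the two is beyond the usual scatter, but the two structures differ in more than one place, so the gap cannot be tied to a single change.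

Compound 3 `CCCCc1noc(-c2ccc(C(=O)NCCC(C)(C)C)cc2)n1` is not yet measured. It differs from compound 2 in one place: butyl in place of phenyl on an aromatic carbon. The butyl it takes on is the same group that compound 1 carries on its five-membered ring, while the amide side of compound 3 stays as in compound 2.

Because compound 1, which carries butyl at that position, gives 9 nM, the step is expected to go toward a lower number, of moderate size and beyond the scatter, estimated as a 4.3-fold lower number from compound 2 to compound 3 (0.64 log units; beyond the scatter). The estimate for compound 3 in this assay is 30 nM, with a range from 8 nM to 100 nM.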

Compound 3, half-maximal inhibitory concentration: 23 nM
Compound 3: the middle estimate sits 1.3-fold (0.12 log units) above what was measured; low and high end bracket the measured number.
By their numbers in this assay, from the lowest: compound 1; then compound 3; then compound 2.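

In this assay, butyl in place of phenyl on the aromatic carbon of the five-membered ring gives a 5.7-fold lower number from compound 2 to compound 3 (0.75 log units; beyond the scatter) with the amide side held fixed, so this position alone moves the number beyond the scatter, which the earlier pair, differing in more than one place, could not show. With butyl held fixed, the amide side also counts: a group of 5 heavy atoms with no ring in place of a group of 7 heavy atoms with a five-membered non-aromatic ring gives a 2.6-fold higher number from compound 1 to compound 3 (0.41 log units; beyond the scatter), so the gap between compound 1 and compound 2 is spread over two places. No measurement in hand bears on why either step takes the size it does.

Only butyl and phenyl are shown on this carbon, so it remains open how a shorter chain such as methyl, a longer chain such as hexyl, or an amine would read in this assay. Also open, going by these compounds, is whether the butyl-for-phenyl step keeps its size on the amide side of compound 1.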